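This account rests on a few compounds, and the source may have more. Where it says the series, first, only, none or still open, it means among the compounds named here.

Measured compounds: compound 1 `Cc1ccc(-c2nn(-c3ccccc3)cc2-c2nc3ccccc3n2S(=O)(=O)c2ccc(Br)cc2)cc1` with 1860 nM; compound 2 `Cc1ccc(-c2nn(-c3ccccc3)cc2-c2nc3ccccc3n2S(=O)(=O)c2ccc(C(F)(F)F)cc2)cc1` with 1460 nM; compound 3 `O=S(=O)(c1ccc(Br)cc1)n1c(-c2cn(-c3ccccc3)nc2-c2ccc(C(F)(F)F)cc2)nc2ccccc21` with 1690 nM. All three were tested in a functional assay on A549 cells (Homo sapiens) for antiproliferative activity, read by MTT assay, with a stated time of 24 h; a higher number here means a weaker inhibitor, a lower number a stronger inhibitor. Compound 4 `O=S(=O)(c1ccc(C(F)(F)F)cc1)n1c(-c2cn(-c3ccccc3)nc2-c2ccc(C(F)(F)F)cc2)nc2ccccc21` remains unmeasured.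

From compound 1 to compound 2 the change is trifluoromethyl in place of bromo on an aromatic carbon, and the step was a 1.3-fold lower number from compound 1 to compound 2 (0.11 log units; within the scatter). The core of compound 3 differs from that of compound 1 by trifluoromethyl in place of methyl on an aromatic carbon, with a step of a 1.1-fold lower number from compound 1 to compound 3 (0.04 log units; within the scatter). Compound 4 carries the same change as compound 2, now on compound 3: trifluoromethyl in place of bromo on an aromatic carbon, at the same place.

The expected step is a 1.3-fold lower number from compound 3 to compound 4 (0.10 log units; within the scatter), set beside a 1.3-fold lower number from compound 1 to compound 2 (0.11 log units; within the scatter), and it rests on compound 3 having 1690 nM as the starting point. Compound 4 is therefore estimated at 1350 nM, expected between 700 nM and 2600 nM.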

Compound 4, half-maximal inhibitory concentration: 860 nM
For compound 4 the middle estimate is 1.6-fold (0.20 log units) above the measured one, and the stated range covers the measured number.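

Trifluoromethyl in place of bromo gives a 2.0-fold lower number from compound 3 to compound 4 (0.29 log units; within the scatter) in this assay, which agrees with the same change on the core of compound 1: the same change on two cores in this assay, a 1.3-fold lower number (0.11 log units; within the scatter) from compound 1 to compound 2 and a 2.0-fold lower number (0.29 log units; within the scatter) from compound 3 to compound 4, 1.5-fold (0.19 log units) apart, within the scatter of two such steps. Trifluoromethyl in place of methyl gives a 1.7-fold lower number from compound 2 to compound 4 (0.23 log units; within the scatter), and this likewise agrees across the two cores: the same change on two cores in this assay, a 1.1-fold lower number (0.04 log units; within the scatter) from compound 1 to compound 3 and a 1.7-fold lower number (0.23 log units; within the scatter) from compound 2 to compound 4, 1.5-fold (0.19 log units) apart, within the scatter of two such steps. Every one of these steps lies within the scatter, so the series shows no detectable difference between cores, but it does not show that either change has a real effect of its own or that the agreement extends to any other core.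

What the compounds shown leave open is how an amine or a carboxylic acid would read in place of the bromo. On these data alone, a longer chain in place of the methyl also remains open.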